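The compounds below may be only part of what the source reports. "The series", "measured", "known", "first", "only" and "open" are said of these compounds alone.

Compound 3, `COc1cc2oc(-c3ccccc3)cc(=O)c2c(O)c1OCCCN1CCCC1`, gives 6000 nM in a functional assay on A549 cells (Homo sapiens) for antiproliferative activity, read by MTT assay, with a stated time of 48 h; a lower number here means a stronger inhibitor, a higher number a weaker inhibitor. Among the three measured compounds it stands second highest: its nearest neighbour is compound 2, `COc1cc2oc(-c3ccccc3)cc(=O)c2c(O)c1OCCCCN1CCCC1`, which gives 13000 nM, while compound 1, `CCN(CC)CCCCOc1c(OCc2ccccc2)cc2oc(-c3ccccc3)cc(=O)c2c1O`, gives 1800 nM and lies furthest away. The one measured step that joins two of these compounds in a single place is a 2.2-fold lower number from compound 2 to compound 3 (0.34 log units; beyond the scatter).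

Compound 4, `CCN(CC)CCCCOc1c(OC)cc2oc(-c3ccccc3)cc(=O)c2c1O`, differs from compound 3 in that it carries (diethylamino)methyl in place of pyrrolidin-1-yl on a saturated chain carbon, three bonds along the chain from an oxygen on an aromatic ring. This change combines the opening of the ring with a lengthening of the chain, and the step from compound 2 to compound 3 covers only the chain length, in the opposite sense: the longer chain there went with the higher number. Within the data shown here, no measured step covers the ring opening itself, and compound 1, which carries the same open-chain amine as compound 4, differs from it in a second place, so its value cannot be read as a direct guide.

On this basis a modest rise in the number is expected, with compound 4 estimated at 8000 nM in this assay, within 3000 nM to 20000 nM, which would mean a step of a 1.3-fold higher number from compound 3 to compound 4 (0.12 log units; within the scatter).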

Compound 4, half-maximal inhibitory concentration: 35000 nM
Compound 4: the middle estimate sits 4.4-fold (0.64 log units) below what was measured; the whole stated range lies below it.
By their numbers in this assay, from the lowest: compound 1; then compound 3; then compound 2; then compound 4.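

With the chain length held, diethylamino in place of pyrrolidin-1-yl, on a saturated chain carbon four bonds along the chain from an oxygen on an aromatic ring, gives a 2.7-fold higher number from compound 2 to compound 4 (0.43 log units; beyond the scatter) in this assay, so the opening of the ring now has a measured direction of its own. The combined change of (diethylamino)methyl in place of pyrrolidin-1-yl gives a 5.8-fold higher number from compound 3 to compound 4 (0.77 log units; beyond the scatter), and both of these steps run upward in this assay, the same way as the earlier chain step read from the shorter chain to the longer. The largest change lies elsewhere on the core: hydrogen in place of phenyl on a saturated chain carbon bound to an oxygen on an aromatic ring gives a 19-fold higher number from compound 1 to compound 4 (1.29 log units; beyond the scatter), which shows that the low number of compound 1 goes with that phenyl and not with its open-chain amine.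

Nothing given here accounts for the size or direction of these steps. On these data alone, it remains open whether a piperidin-1-yl or morpholin-4-yl amine would follow the same direction, how a 3-(diethylamino)propyl chain would compare, and whether the phenyl step would hold on a pyrrolidin-1-yl compound.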